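The source may hold more compounds than are shown below. What is called first, only, known or untested is meant among the compounds shown, and "the series" means these compounds.

Compound 1 `CC(C)[C@H](NC(=O)COc1cccc2ccccc12)C(=O)N[C@@H](CC(=O)O)C(=O)COc1ccc(C(F)(F)F)cc1`: in a functional assay on Jurkat cells (Homo sapiens) (a higher number here means a weaker inhibitor, a lower number a stronger inhibitor), compound 1 gives > 100000 nM, which is a limit of the assay and not a number.
Compound 2 `CC(C)[C@H](NC(=O)COc1cccc2ccccc12)C(=O)N[C@@H](CC(=O)O)C(=O)COc1cccc(F)c1`: in this assay compound 2 gives > 100000 nM, again a limit of the assay.

Compound 2 therefore stands at the limit of > 100000 nM in this assay, at which 2 of the 2 values shown sit, and nothing more exact is known of its potency. Compound 3 `CC(C)[C@H](NC(=O)COc1cccc2ccccc12)C(=O)N[C@@H](CC(=O)O)C(=O)COc1c(F)ccc(F)c1F` is the next member of the series; the change from compound 2 is 2,3,6-trifluorophenyl in place of 3-fluorophenyl on an oxygen on a saturated carbon. Going by the values given here, the only measured step, a step that the two limits leave unreadable from compound 1 to compound 2, bears on this change only loosely, and its size cannot be read from two limits, so no direction can be drawn from it. Given that both measured compounds sit at the same limit, compound 3 is expected to behave alike, with an expected step of a number no higher from compound 2 to compound 3 (the limit leaves the size open), that is, none beyond the scatter. Compound 3 is estimated at 100000 nM, in a range from 20000 nM to 300000 nM, and most likely as a limit again.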

Compound 3, half-maximal inhibitory concentration: 1200 nM
The estimate for compound 3 lay 83-fold (1.92 log units) above the measured number; measured number outside the range, below it.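

At the position on an oxygen on a saturated carbon, the aryl group proves able to decide whether any activity appears at all in this assay: 2,3,6-trifluorophenyl gives an at least 83-fold lower number from compound 2 to compound 3 (1.92 log units; beyond the scatter), and set against 4-(trifluoromethyl)phenyl it gives an at least 83-fold lower number from compound 1 to compound 3 (1.92 log units; beyond the scatter). From the compounds shown here alone, both steps start from a limit of the assay, so their full size stays open, and the step between the two limited compounds cannot be read. Fluorine on the ring is thus not enough in itself, as the single fluorine of 3-fluorophenyl leaves compound 2 at a limit, and only compound 3 gives a number: the limit of > 100000 nM in this assay, at which 2 of the 3 values shown sit.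

The compounds shown do not tell whether all of the fluorines in 2,3,6-trifluorophenyl are needed, or only some of them. Going by these compounds, how a plain phenyl or a chlorophenyl would read at this position also remains open.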